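Aryl Methyl Added Beside Nothing Printed: A Sulfonamide Agonist Series

The source may report more compounds than this note shows. Statements on the series, on what has been measured and on what is new or still open speak of the compounds shown alone.

Compound 1 `Cc1cc2c(c(Oc3cccc(NS(=O)(=O)c4ccc(Cl)cc4)c3)n1)C(=O)N(C(C)C)C2=O` in a functional assay on HEK293 cells for agonist activity at Glucose-dependent insulinotropic receptor (Homo sapiens), read by cAMP accumulation, with a stated time of 30 min (on this read-out higher numbers stand for an effect only at larger amounts of compound and lower numbers for an effect already at smaller amounts), gives 13 nM. Compound 3 `Cc1cc2c(c(Oc3cccc(N(C)S(=O)(=O)c4ccc(Cl)cc4)c3)n1)C(=O)N(C(C)C)C2=O` gives 11 nM. Compound 2 `Cc1cc2c(c(Oc3cccc(NC(=O)c4ccc(Cl)cc4)c3)n1)C(=O)N(C(C)C)C2=O` gives only a limit of the assay, > 30000 nM.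

Compound 1 holds the highest of the two numbers, its nearest neighbour being compound 3, and a 1.2-fold lower number from compound 1 to compound 3 (0.07 log units; within the scatter), so the two cannot be ordered. The step from compound 1 to compound 2 replaces the sulfonyl link with a carbonyl, and an at least 2300-fold higher number from compound 1 to compound 2 (3.36 log units; beyond the scatter) shows how far that change reaches, ending at a limit of the assay (the limit of > 30000 nM in this assay, at which 1 of the 3 values shown sits).

Compound 4 `Cc1cc2c(c(Oc3ccc(C)c(NS(=O)(=O)c4ccc(Cl)cc4)c3)n1)C(=O)N(C(C)C)C2=O` keeps the sulfonamide of compound 1 intact and changes the phenoxy ring instead: methyl in place of hydrogen on an aromatic carbon, the methyl sitting ortho to the ((4-chlorophenyl)sulfonyl)amino group and para to a large group. Among the compounds with values here, no measured step touches that ring. The step from compound 1 to compound 3 shows a methyl tolerated on the sulfonamide nitrogen, while the step from compound 1 to compound 2 concerns the linking group, not the ring. With nothing pointing toward a shift, the expected step of a 1.2-fold higher number from compound 1 to compound 4 (0.06 log units; within the scatter) is none beyond the scatter. Compound 4 is therefore estimated at 15 nM, with a range from 4 nM to 70 nM in this assay.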

Compound 4, half-maximal effective concentration: 9 nM
For compound 4 the middle estimate is 1.7-fold (0.22 log units) above the measured one, within the range that was stated.
By their numbers in this assay, from the lowest: compounds 4, 3 and 1 (each within the scatter of the next). At a limit, above all of these: compound 2.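

In this assay, within the data shown here, the methyl on an aromatic carbon, ortho to a ((4-chlorophenyl)sulfonyl)amino group and para to a large group, gives a 1.4-fold lower number from compound 1 to compound 4 (0.16 log units; within the scatter) and is the first measured change on the phenoxy ring, so this position accepts a methyl in place of hydrogen with no step that can be read. Compound 1 has now taken a methyl at two separate places without a readable step, on the sulfonamide nitrogen in compound 3 and on this ring in compound 4, and neither compound goes against that short pattern. Nothing measured here explains why the ring methyl is tolerated.

The compounds shown leave open whether this position would also accept a chlorine atom, a methoxy group or an ethyl chain, and whether the other carbons of the phenoxy ring would take the same methyl. They also leave open whether the ring methyl and the sulfonamide nitrogen methyl can stand together in one compound, and what the ring methyl would do alongside the carbonyl link of compound 2.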